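Series notes: the step from compound 2 to compound 4

A few compounds are considered here, and "the series" means these few. Any claim that something is new, unique, unknown or untested is made for them only; others in the source may bear on it.

Measured so far in a functional assay on HL-60 cells (Homo sapiens) for antiproliferative activity; on this read-out higher numbers stand for weaker inhibition and lower numbers for stronger inhibition:
Compound 1, `N=C(NO)N/N=C/c1ccc(Cl)cc1`, gives > 100000 nM, which is a limit of the assay.
Compound 2, `CN(C)c1ccc(/C=N/NC(=N)NO)cc1`, gives > 100000 nM, which is a limit of the assay.
Compound 3, `COc1ccccc1/C=N/N=C(\N)NO`, gives > 100000 nM, which is a limit of the assay.

Compound 2 therefore stands where every measured compound of the series stands: at the limit, with no number beneath it. Among the compounds with values here, the only single-point step measured, a step that the two limits leave unreadable from compound 1 to compound 2, runs from one limit to another, so its size cannot be read. The same holds for the whole set, because the limit of > 100000 nM in this assay, at which 3 of the 3 values shown sit, gathers all three values shown.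

Compound 4, `COc1ccc(/C=N/NC(=N)NO)cc1`, arises from compound 2 by the change (methoxy in place of dimethylamino on an aromatic carbon). Within the data shown here, no measured step speaks to this change with a readable size; the sole neighbouring comparison is unreadable, and the remaining compounds give nothing but limits. The expectation for the step that the limit leaves unreadable from compound 2 to compound 4 in this assay is accordingly none beyond the scatter, with compound 4 expected to remain at the limit. Compound 4 is estimated at 150000 nM, with a range from 50000 nM to 500000 nM, and most probably reported only as a limit.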

Compound 4, half-maximal inhibitory concentration: > 100000 nM
Compound 4 was reported as a limit; the forecaster's own chance of this, stated with the estimate: 88%; the middle value is on the limit's open side.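

In this assay, within the data shown here, compound 4 gives > 100000 nM, which is a limit, so no step from compound 1 or compound 2 to compound 4 can be read. The compounds shown leave open whether any change on the shared core gives a readable value, since all of them gather at one point: the limit of > 100000 nM in this assay, at which 4 of the 4 values shown sit.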